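The compounds below may be only part of what the source reports. "The series", "measured", "known", "first", "only" and "open" are said of these compounds alone.

Series notes. Compound 1 `Cn1c(-c2ccc([N+](=O)[O-])cc2)nc2cc(C(F)(F)F)ccc21` is run in an ADME assay on MT4 cells (Homo sapiens) for cytotoxicity, read by MTT assay, with a stated time of 96 h; a lower number here means that less compound is tolerated, a higher number that more compound is tolerated; compound 1 gives >= 100000 nM, which is a limit of the assay and not a number. Compound 2 `O=[N+]([O-])c1ccc(-c2nc3cc(C(F)(F)F)ccc3[nH]2)cc1` gives 6000 nM in this assay, and compound 3 `Cn1c(-c2ccc(NC(=O)CN3CCCCC3)cc2)nc2cc(C(F)(F)F)ccc21` gives 9000 nM. The step of an at least 16-fold lower number from compound 1 to compound 2 (1.22 log units; beyond the scatter) is hydrogen in place of methyl on an aromatic nitrogen; its size is only bounded because of the limit of >= 100000 nM in this assay, at which 1 of the 3 values shown sits. The step of an at least 11-fold lower number from compound 1 to compound 3 (1.04 log units; beyond the scatter) is (((piperidin-1-yl)methyl)carbonyl)amino in place of nitro on an aromatic carbon, and this is also how the cores of compound 3 and compound 1 differ. Compound 4 `O=C(CN1CCCCC1)Nc1ccc(-c2nc3cc(C(F)(F)F)ccc3[nH]2)cc1` is not yet measured; it differs from compound 3 by hydrogen in place of methyl on an aromatic nitrogen, the same kind of change as from compound 1 to compound 2, though the earlier site is next to the ring atom that bears a group of 9 heavy atoms and the new one next to the ring atom that bears a large group. Compound 2 at 6000 nM and compound 3 at 9000 nM sit within the scatter of each other, so a smaller step is looked for. In this assay the expected step is a 2.3-fold lower number from compound 3 to compound 4 (0.35 log units; beyond the scatter). Compound 4 is estimated at 4000 nM, between 1500 nM and 10000 nM.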

Compound 4, half-maximal cytotoxic concentration: 6000 nM
The estimate for compound 4 lay 1.5-fold (0.18 log units) below the measured number; the measured number falls inside the stated range.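

In this assay, hydrogen in place of methyl on an aromatic nitrogen gives a 1.5-fold lower number from compound 3 to compound 4 (0.18 log units; within the scatter), so the size of the step on the core of compound 1 does not carry over to the core of compound 3: the same change on two cores in this assay, an at least 16-fold lower number (1.22 log units; beyond the scatter) from compound 1 to compound 2 and a 1.5-fold lower number (0.18 log units; within the scatter) from compound 3 to compound 4, at least 11-fold (1.04 log units) apart, beyond the scatter of two such steps. The earlier step is only bounded, and compound 1 stands at a limit of the assay: the limit of >= 100000 nM in this assay, at which 1 of the 4 values shown sits. These two pairs show that the step differs between these cores, but not what sets that difference, and they give no rule for the series.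

Open, on these data alone, is how the same change behaves with an amine or a carboxylic acid in place of nitro on the aromatic carbon. Also open, as far as these compounds go, is whether ethyl on the aromatic nitrogen would follow either step.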